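Anilino aryl swap in a flat antiproliferative series

The source may hold more compounds than are shown below. What is called first, only, known or untested is meant among the compounds shown, and "the series" means these compounds.

Compound 1 `O=C(C1=C(O)C(=O)N(CCCn2ccnc2)C1c1ccc(Br)cc1)c1ccccc1` gives 20000 nM in a functional assay on NCI-H1299 cells (Homo sapiens) for antiproliferative activity, read by MTT assay, with a stated time of 72 h; a higher number here means a weaker inhibitor, a lower number a stronger inhibitor. Compound 2 `CC(C)OC1=C(C(=O)c2ccccc2)C(c2ccc(Br)cc2)N(CCCn2ccnc2)C1=O` gives 18900 nM there, and compound 3 `CCOc1ccc(NC2=C(C(=O)c3ccccc3)C(c3ccc(Br)cc3)N(CCCn3ccnc3)C2=O)cc1` gives 20000 nM. Compound 3 thus stands level with compound 1, the two together the highest of the three numbers, with no change at the digits printed from compound 1 to compound 3 (within the scatter) and a 1.1-fold higher number from compound 2 to compound 3 (0.02 log units; within the scatter) both inside the scatter, as is a 1.1-fold lower number from compound 1 to compound 2 (0.02 log units; within the scatter). Compound 4 `O=C(C1=C(Nc2cccc(Br)c2)C(=O)N(CCCn2ccnc2)C1c1ccc(Br)cc1)c1ccccc1` differs from compound 3 by 3-bromophenyl in place of 4-ethoxyphenyl on an amine nitrogen. Within the data shown here, the measured steps at this position, the one from compound 1 to compound 3 and the one from compound 2 to compound 3, were both flat, so no step beyond the scatter is expected in this assay, that is no change at the digits printed from compound 3 to compound 4 (within the scatter). Compound 4 is accordingly estimated at 20000 nM, within 9000 nM to 45000 nM.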

Compound 4, half-maximal inhibitory concentration: 11500 nM
For compound 4 the middle estimate is 1.7-fold (0.24 log units) above the measured one; the measured number falls inside the stated range.
By their numbers in this assay, from the lowest: compounds 4, 2, 1 and 3 (each within the scatter of the next).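

In this assay, the aryl group on the amine nitrogen can be exchanged, with 3-bromophenyl in place of 4-ethoxyphenyl, and the result stays inside the scatter, at a 1.7-fold lower number from compound 3 to compound 4 (0.24 log units; within the scatter). The (3-bromophenyl)amino group also stays inside the scatter against isopropoxy, at a 1.6-fold lower number from compound 2 to compound 4 (0.22 log units; within the scatter), and against hydroxy, at a 1.7-fold lower number from compound 1 to compound 4 (0.24 log units; within the scatter). This position therefore remains flat across four compounds, now including two different aryl groups on the amine nitrogen. No supporting data bear on why these numbers sit together. On these data alone, whether a carboxylic acid on that aryl ring, or a longer alkyl chain in its place, would give a step beyond the scatter remains open.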